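The compounds below may be only part of what the source reports. "The series", "measured", "known", "first", "only" and "open" are said of these compounds alone.

Of the compounds shown here, two have a number so far, and a third waits for its turn. Compound 1 `CO[C@]1(c2cc(F)cc(S(=O)(=O)c3ccc(/C(C)=N/O)cc3)c2)CCO[C@@H](C)C1` and compound 2 `CC(C)/C(=N\O)c1ccc(Sc2cc(F)cc(C3CCOCC3)c2)cc1` were both tested in a functional assay (blood) for inhibition, with Homo sapiens as the target; a lower number here means a stronger inhibitor, a higher number a weaker inhibitor. Compound 1 gives 20 nM. Compound 2 gives 300 nM, the higher of the two numbers, and the gap to compound 1 is beyond the usual scatter, so compound 2 is the weaker inhibitor of the pair.

Compound 3 `C/C(=N\OC(=O)N(C)C)c1ccc(Sc2cc(F)cc(C3CCOCC3)c2)cc1` has not been measured. It is built from compound 2 by one change: a group of 9 heavy atoms (5 carbon, 2 nitrogen, 2 oxygen; no ring) in place of a group of 6 heavy atoms (4 carbon, 1 nitrogen, 1 oxygen; no ring), on an aromatic carbon. The part that leaves carries one hydrogen-bond donor; the part that enters carries none and holds one more hydrogen-bond acceptor and one more double bond outside aromatic rings. Among the compounds with values here, no measured pair shows this exact change, so nothing here tells how large its effect is. Without such a comparison, the expected step in this assay from compound 2 to compound 3 is put at a 1.7-fold higher number from compound 2 to compound 3 (0.22 log units; within the scatter), a modest move toward a higher number that could still fall within the scatter. For compound 3 the estimate in this assay is 500 nM, with a range from 150 nM to 1500 nM.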

Compound 3, half-maximal inhibitory concentration: 2610 nM
The estimate for compound 3 lay 5.2-fold (0.72 log units) below the measured number; the whole stated range lies below it.
By their numbers in this assay, from the lowest: compound 1; then compound 2; then compound 3.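

In this assay, exchanging the group on an aromatic carbon of a six-membered aromatic ring of carbon only, para to a large group, gives an 8.7-fold higher number from compound 2 to compound 3 (0.94 log units; beyond the scatter), a step beyond the scatter. Within the data shown here, this is the first pair that differs in one place, and it shows that this position is not indifferent to what it carries: the entering group, with 9 heavy atoms and 0 hydrogen-bond donors, gives a weaker inhibitor than the leaving group, with 6 heavy atoms and 1 hydrogen-bond donor. No measurement here gives a reason for this loss of strength.

The single exchange alters size, hydrogen-bond donors, hydrogen-bond acceptors and double bonds together, so the compounds shown cannot say which of these differences goes with the step. From the compounds shown here alone, it also remains open how inhibition would respond at this same position to other groups, such as a nitrile, a carboxylic acid or a primary amine, and whether the step would keep its size on the core of compound 1.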